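The compounds below may be only part of what the source reports. "The series", "measured", "known", "first", "only" and "open" are said of these compounds alone.

Measured in a functional assay on HeLa cells (Homo sapiens) for antiproliferative activity, read by CCK-8 assay, with a stated time of 72 h; on this read-out lower numbers stand for stronger inhibition and higher numbers for weaker inhibition:
compound 1 `Cc1ccccc1C(=O)Nc1cccc(-c2oc3cc(-c4ccc(F)cc4)ccc3c(=O)c2O)c1` — 11900 nM
compound 2 `COc1cccc(C(=O)Nc2cccc(-c3oc4cc(-c5ccc(F)cc5)ccc4c(=O)c3O)c2)c1` — 5650 nM
compound 3 `Cc1cc(C(=O)Nc2cccc(-c3oc4cc(-c5ccc(F)cc5)ccc4c(=O)c3O)c2)ccc1F` — 18900 nM

Compound 3 carries the highest number of the three. Its gap to compound 1 lies within the scatter, whereas the step of a 3.3-fold higher number from compound 2 to compound 3 (0.52 log units; beyond the scatter) lies beyond it, as does a 2.1-fold lower number from compound 1 to compound 2 (0.32 log units; beyond the scatter).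

Compound 4 `N#Cc1ccc(C(=O)Nc2cccc(-c3oc4cc(-c5ccc(F)cc5)ccc4c(=O)c3O)c2)cc1` is not yet measured. It differs from compound 3 in one place: 4-cyanophenyl in place of 4-fluoro-3-methylphenyl on a carbonyl carbon. Among the compounds with values here, no measured step introduces a nitrile-bearing ring on the carbonyl carbon. Within the data shown here, the steps of a 2.1-fold lower number from compound 1 to compound 2 (0.32 log units; beyond the scatter) and a 3.3-fold higher number from compound 2 to compound 3 (0.52 log units; beyond the scatter) show only that exchanging the aryl group on the carbonyl carbon shifts this assay by modest amounts, and a 1.6-fold higher number from compound 1 to compound 3 (0.20 log units; within the scatter) shows one such exchange staying within the scatter. A modest move toward a lower number, or none beyond the scatter, is therefore expected. Compound 4 is estimated at 12000 nM (range 4000 nM to 35000 nM), an expected step of a 1.6-fold lower number from compound 3 to compound 4 (0.20 log units; within the scatter).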

Compound 4, half-maximal inhibitory concentration: 23300 nM
Compound 4: the middle estimate sits 1.9-fold (0.29 log units) below what was measured; the range from low to high includes it.
By their numbers in this assay, from the lowest: compound 2; then compounds 1, 3 and 4 (each within the scatter of the next).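

In this assay, within the data shown here, a nitrile-bearing ring on the carbonyl carbon appears for the first time, and both a 1.2-fold higher number from compound 3 to compound 4 (0.09 log units; within the scatter) and a 2.0-fold higher number from compound 1 to compound 4 (0.29 log units; within the scatter) stay within the scatter, so at this position 4-cyanophenyl is not separated from 4-fluoro-3-methylphenyl or 2-methylphenyl. Of the aryl groups shown, only 3-methoxyphenyl stands apart from it, with a 4.1-fold higher number from compound 2 to compound 4 (0.62 log units; beyond the scatter) beyond the scatter. No evidence at hand accounts for this difference.

The compounds shown leave open whether an amine, a carboxylic acid or a longer chain in place of these aryl groups would shift the number in this assay further than 3-methoxyphenyl does.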